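Benzothiazole in Place of Imidazole: Expected to Stay Beyond Limit

The source may hold more compounds than are shown below. What is called first, only, known or untested is meant among the compounds shown, and "the series" means these compounds.

Three compounds share one core and differ only in the aromatic group attached to a sulfur. Compound 1, `CC(C)[C@H](NC(=O)COc1cccc2ccccc12)C(=O)N[C@@H](CC(=O)O)C(=O)CSc1nccn1C`, carries a 1-methyl-1H-imidazol-2-yl there. In a functional assay on Jurkat cells (Homo sapiens) for inhibition (on this read-out higher numbers stand for weaker inhibition and lower numbers for stronger inhibition), compound 1 gives > 200000 nM, which is a limit of the assay and not a measured number. Compound 2, `CC(C)[C@H](NC(=O)COc1cccc2ccccc12)C(=O)N[C@@H](CC(=O)O)C(=O)CSc1nnnn1C`, carries a 1-methyl-1H-tetrazol-5-yl instead. In this assay compound 2 gives > 200000 nM, again a limit. Compound 3, `CC(C)[C@H](NC(=O)COc1cccc2ccccc12)C(=O)N[C@@H](CC(=O)O)C(=O)CSc1nc2ccccc2o1`, carries a 1,3-benzoxazol-2-yl. In this assay compound 3 gives > 200000 nM, also a limit. Compound 1 therefore stands nowhere in particular among these values: all three sit at the limit of > 200000 nM in this assay, at which 3 of the 3 values shown sit, and the steps a step that the two limits leave unreadable from compound 1 to compound 2, a step that the two limits leave unreadable from compound 1 to compound 3 and a step that the two limits leave unreadable from compound 2 to compound 3 cannot be read in size or direction.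

Compound 4, `CC(C)[C@H](NC(=O)COc1cccc2ccccc12)C(=O)N[C@@H](CC(=O)O)C(=O)CSc1nc2ccccc2s1`, is compound 1 with 1,3-benzothiazol-2-yl in place of 1-methyl-1H-imidazol-2-yl on a sulfur. The closest measured comparison is a step that the two limits leave unreadable from compound 1 to compound 3, where 1,3-benzoxazol-2-yl entered on the same sulfur. Among the compounds with values here, no measured step shows a readable gain or loss, so no movement beyond the scatter can be predicted, and it is expected that a step that the limit leaves unreadable from compound 1 to compound 4 will again end at a limit. The estimated value for compound 4 is 300000 nM, with an expected range from 120000 nM to 1000000 nM.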

Compound 4, half-maximal inhibitory concentration: > 200000 nM
Compound 4 gave a limit, no number (the forecaster's own chance of this, stated with the estimate: 85%); the middle value lies beyond the limit too.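

In this assay compound 4 gives > 200000 nM, which is a limit of the assay and not a measured number. Its steps from compound 1, compound 2 and compound 3 therefore cannot be read in size or direction: the limit of > 200000 nM in this assay, at which 4 of the 4 values shown sit. The compounds shown leave open whether any of these four groups on the sulfur differs from another in inhibition, and at what concentration any of them would inhibit.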